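Moving the bromine around the ring on a shared core

This account rests on a few compounds, and the source may have more. Where it says the series, first, only, none or still open, it means among the compounds named here.

Compound 1 `CC(C)[C@H](NC(=O)c1ccccc1Br)C(=O)N1CCC[C@H]1C(=O)N[C@@H](CCCNC(=N)N)C(=O)CF` and compound 2 `CC(C)[C@H](NC(=O)c1cccc(Br)c1)C(=O)N1CCC[C@H]1C(=O)N[C@@H](CCCNC(=N)N)C(=O)CF` share one core and differ only in where the bromine sits on the phenyl ring attached to the carbonyl carbon. In a functional assay on OCI-Ly3 cells (Homo sapiens) for inhibition, read by CellTiter-Glo, with stated times of 48 h and 96 h (a higher number here means a weaker inhibitor of growth, a lower number a stronger inhibitor of growth), compound 1 gives 4240 nM, while compound 2 gives 530 nM. For the measured compounds named here, the single measured step, an 8.0-fold lower number from compound 1 to compound 2 (0.90 log units; beyond the scatter), came from putting 3-bromophenyl in place of 2-bromophenyl. Going by the values given here, compound 2 therefore stands at the lowest number of the two, with compound 1 as its only neighbour, well beyond the scatter.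

Compound 3 `CC(C)[C@H](NC(=O)c1ccc(Br)cc1)C(=O)N1CCC[C@H]1C(=O)N[C@@H](CCCNC(=N)N)C(=O)CF` is a third arrangement of the same atoms: 4-bromophenyl in place of 3-bromophenyl on a carbonyl carbon. Among the compounds with values here, the one measured step, an 8.0-fold lower number from compound 1 to compound 2 (0.90 log units; beyond the scatter), shows that shifting the bromine can move the number well beyond the scatter, but it concerns a different shift, and nothing measured speaks directly to the move from 3-bromophenyl to 4-bromophenyl. The expected step of a 1.3-fold lower number from compound 2 to compound 3 (0.12 log units; within the scatter) is therefore small, within the scatter, leaning slightly toward a lower number. Compound 3 is estimated at 400 nM in this assay, with a range from 100 nM to 2000 nM.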

Compound 3, concentration for 50% growth inhibition: 130 nM
Estimate against measurement, compound 3: 3.1-fold (0.49 log units) above; the measured number falls inside the stated range.
By their numbers in this assay, from the lowest: compound 3; then compound 2; then compound 1.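

Across the three arrangements, the position of the bromine gives a clear order in this assay: the number falls from 2-bromophenyl to 3-bromophenyl to 4-bromophenyl, and none of the three compounds goes against that order. The new shift (a 4.1-fold lower number from compound 2 to compound 3 (0.61 log units; beyond the scatter)) is beyond the scatter, so even the two arrangements that stood closest in the estimate can be told apart, and the full span (a 33-fold lower number from compound 1 to compound 3 (1.51 log units; beyond the scatter)) is large although the atoms stay the same and only the way they are joined changes, which makes compound 3 the strongest inhibitor of growth of the three. Nothing available here explains why the numbers fall in this order.

The compounds shown carry only bromine on this ring, so they leave open whether the order belongs to bromine itself or would hold for another group, such as a chlorine, a methoxy group or a carboxylic acid in its place. From the compounds shown here alone, it is also open how plain phenyl, with no bromine at all, would compare with 4-bromophenyl on the same core.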